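Where a Shared Core Meets a Basic Side Chain

The compounds below may be only part of what the source reports. "The series", "measured", "known", "first", "only" and "open" are said of these compounds alone.

Three compounds share one core. Compound 1 `Oc1ccc(-c2nc3cc(C(F)(F)F)ccc3[nH]2)cc1` carries a hydroxy group on an aromatic carbon, compound 2 `CCC(=O)Nc1ccc(-c2nc3cc(C(F)(F)F)ccc3[nH]2)cc1` a propanoylamino group in its place, and compound 3 `O=C(O)CCC(=O)Nc1ccc(-c2nc3cc(C(F)(F)F)ccc3[nH]2)cc1` a ((2-carboxyethyl)carbonyl)amino group. In an ADME assay on Vero cells (Chlorocebus sabaeus) for cytotoxicity (on this read-out higher numbers stand for lower toxicity in this test and lower numbers for higher toxicity in this test), compound 1 gives > 100000 nM, which is a limit of the assay and not a number. In this assay compound 2 also gives only the limit > 100000 nM. In this assay compound 3 likewise gives only the limit > 100000 nM. All three values sit at the limit of > 100000 nM in this assay, at which 3 of the 3 values shown sit, so the steps a step that the two limits leave unreadable from compound 1 to compound 2, a step that the two limits leave unreadable from compound 1 to compound 3 and a step that the two limits leave unreadable from compound 2 to compound 3 remain without a readable size, and no direction can be read from them.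

Compound 4 `CCN(CC)CC(=O)Nc1ccc(-c2nc3cc(C(F)(F)F)ccc3[nH]2)cc1` has not yet been measured. It differs from compound 3 by diethylamino in place of carboxymethyl on a saturated chain carbon bound to a carbonyl carbon. Going by the values given here, since every compound measured so far sits at the limit of > 100000 nM in this assay, at which 3 of the 3 values shown sit, none of the measured steps offers a size to carry over to this change. The expectation is therefore that compound 4 also stays at the limit, with a number no higher from compound 3 to compound 4 (the limit leaves the size open) expected to lie within the scatter. In this assay compound 4 is estimated at 100000 nM, with a range from 40000 nM to 250000 nM.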

Compound 4, half-maximal cytotoxic concentration: 24000 nM
The estimate for compound 4 lay 4.2-fold (0.62 log units) above the measured number; measured number below the stated range.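

In this assay, the saturated chain carbon bound to a carbonyl carbon proves able to shift the read-out: diethylamino in place of carboxymethyl gives an at least 4.1-fold lower number from compound 3 to compound 4 (0.61 log units; beyond the scatter), and diethylamino in place of methyl gives an at least 4.1-fold lower number from compound 2 to compound 4 (0.61 log units; beyond the scatter). The (((diethylamino)methyl)carbonyl)amino group in place of hydroxy on an aromatic carbon gives an at least 4.1-fold lower number from compound 1 to compound 4 (0.61 log units; beyond the scatter), so all three comparisons point the same way, towards higher toxicity in this test. Compound 4 thus gives the first readable step in the set, while the steps among compound 1, compound 2 and compound 3 still cannot be read, and the full size of each new step stays hidden behind a limit: the limit of > 100000 nM in this assay, at which 3 of the 4 values shown sit.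

The compounds shown leave open whether the step depends on the diethylamino group as a whole or on any amine at this place, a question that an unsubstituted amine, a dimethylamino group or a longer chain carrying the diethylamino group could address. They also leave open whether an amine on the same chain would give a comparable step with a hydroxy group in place of the amide on the aromatic carbon.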